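The source may report more compounds than this note shows. Statements on the series, on what has been measured and on what is new or still open speak of the compounds shown alone.

Compound 1 `O=C(Nc1ccccc1O)c1cccc(N2C(=O)c3ccccc3C2=O)c1` is the only one of the three measured compounds that gives a number in an in vitro functional assay on HEK293-A cells for antagonist activity at metabotropic glutamate receptor 5 (Rattus norvegicus), read by calcium flux (a higher number here means a weaker inhibitor, a lower number a stronger inhibitor), where compound 1 gives 77 nM. Compound 2 `O=C(Nc1cccc(NC(=O)c2cccc(Cl)c2)c1)c1ccc(Cl)cc1` reaches only a limit of the assay, > 30000 nM. Compound 3 `O=C(Nc1cccc(NC(=O)c2cccc(Cl)c2)c1)c1ccc(F)cc1` likewise sits at a limit, > 30000 nM. For the measured compounds named here, the single step between measured compounds, a step that the two limits leave unreadable from compound 2 to compound 3, cannot be read in size because the limit of > 30000 nM in this assay, at which 2 of the 3 values shown sit, covers both of its ends. Compound 4 `COc1cc(NC(=O)c2cccc(N3C(=O)c4ccccc4C3=O)c2)cc(OC)c1` keeps the core of compound 1 and differs in one place: 3,5-dimethoxyphenyl in place of 2-hydroxyphenyl on an amide-type nitrogen. Going by the values given here, no measured step touches this kind of change, since the only measured step concerns a halogen swap between compound 2 and compound 3 and gives no size. The expectation therefore rests on compound 1 alone, with wide uncertainty. For compound 4 a modest loss of potency is estimated, a 6.5-fold higher number from compound 1 to compound 4 (0.81 log units; beyond the scatter). Compound 4 is expected to give about 500 nM in this assay, with a likely range from 80 nM to 5000 nM.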

Compound 4, half-maximal inhibitory concentration: 3580 nM
Beside the measured number, compound 4's estimate is 7.2-fold (0.85 log units) below it; measured number inside the range.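

The group on the amide-type nitrogen matters a great deal: in this assay, putting 3,5-dimethoxyphenyl in place of 2-hydroxyphenyl gives a 46-fold higher number from compound 1 to compound 4 (1.67 log units; beyond the scatter). For the compounds shown here, this is the first step whose size can be read, as the earlier halogen swap lay entirely at the assay limit. The core of compound 1 alone therefore does not set the potency, although compound 4 still gives a real number in this assay rather than a limit.

The swap removes a hydrogen-bond donor and brings in two methoxy groups at once, and nothing measured here shows which of these differences accounts for the loss. On these data alone, how a plain phenyl, or a phenyl ring carrying an amine or a carboxylic acid, would behave on this nitrogen remains open.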